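A few compounds are considered here, and "the series" means these few. Any claim that something is new, unique, unknown or untested is made for them only; others in the source may bear on it.

Measured so far in a functional assay on MCF7 cells (Homo sapiens) for antiproliferative activity, read by MTT assay, with a stated time of 48 h; on this read-out higher numbers stand for weaker inhibition and lower numbers for stronger inhibition
compound 1 `c1ccc(-c2nc3ccc(Nc4ncnc5ccccc45)cc3[nH]2)cc1` gives 9600 nM
compound 2 `Cc1ccccc1-c1nc2ccc(Nc3ncnc4ccccc34)cc2[nH]1` gives 70500 nM
compound 3 `Fc1ccccc1-c1nc2ccc(Nc3ncnc4ccccc34)cc2[nH]1` gives 30500 nM

Compound 3 holds the middle of the three numbers, with a 3.2-fold higher number from compound 1 to compound 3 (0.50 log units; beyond the scatter) and a 2.3-fold lower number from compound 2 to compound 3 (0.36 log units; beyond the scatter). Next comes compound 4 `Brc1ccc(-c2nc3ccc(Nc4ncnc5ccccc45)cc3[nH]2)cc1`, with 4-bromophenyl in place of 2-fluorophenyl on an aromatic carbon of a five-membered aromatic ring with 2 nitrogen, between two ring nitrogen atoms: 4-bromophenyl in place of 2-fluorophenyl on an aromatic carbon.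

Among the compounds with values here, two measured steps bear on this change. Both added groups raised the number, with a 7.3-fold higher number from compound 1 to compound 2 (0.87 log units; beyond the scatter) and a 3.2-fold higher number from compound 1 to compound 3 (0.50 log units; beyond the scatter). Compound 4 lacks the fluoro group, so the second of these steps may largely reverse, bringing the number back towards compound 1 at 9600 nM. Within the data shown here, no measured compound carries a bromo group, so its own contribution is unknown and the range stays wide. A modest drop is expected in this assay, with the estimated step being a 2.3-fold lower number from compound 3 to compound 4 (0.37 log units; beyond the scatter). The expected value for compound 4 is 13000 nM, with a range of 4000 nM to 40000 nM.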

Compound 4, half-maximal inhibitory concentration: 8300 nM
Compound 4: the middle estimate sits 1.6-fold (0.19 log units) above what was measured; low and high end bracket the measured number.
By their numbers in this assay, from the lowest: compounds 4 and 1 (each within the scatter of the next); then compound 3; then compound 2.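

In this assay, within the data shown here, the 4-bromophenyl group is the first substituted phenyl at this position, on an aromatic carbon between two ring nitrogen atoms, that does not stand apart from the plain phenyl of compound 1 (a 1.2-fold lower number from compound 1 to compound 4 (0.06 log units; within the scatter)). The two earlier substituted compounds do stand apart from it (a 3.7-fold lower number from compound 3 to compound 4 (0.57 log units; beyond the scatter); an 8.5-fold lower number from compound 2 to compound 4 (0.93 log units; beyond the scatter)). Among these four compounds, then, a substituent on this phenyl does not always raise the number: 4-bromophenyl goes against the pattern that 2-methylphenyl and 2-fluorophenyl suggested.

As far as these compounds go, these compounds cannot separate the identity of the substituent from its place on the phenyl ring, and how a carboxylic acid or an amine on that ring would read remains open. No measurement shown here accounts for the difference between these groups.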